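Moving a fluorine on a benzyl group at two places

The source may report more compounds than this note shows. Statements on the series, on what has been measured and on what is new or still open speak of the compounds shown alone.

Compound 1 `Fc1ccccc1COc1ccc(-c2cc(CN3CCN(Cc4ccc(C(F)(F)F)cc4)CC3)no2)cc1` and compound 2 `Fc1cccc(COc2ccc(-c3cc(CN4CCN(Cc5ccc(C(F)(F)F)cc5)CC4)no3)cc2)c1` share a core and differ only where a benzyl group sits on an oxygen. In a functional assay on Mahlavu cells (Homo sapiens) for antiproliferative activity, read by sulforhodamine B assay, with a stated time of 72 h (a lower number here means a stronger inhibitor, a higher number a weaker inhibitor), compound 1 gives 3100 nM, and compound 2 gives 2900 nM. The change between them is 3-fluorophenyl in place of 2-fluorophenyl on a saturated chain carbon bound to an oxygen on an aromatic ring, and its step is a 1.1-fold lower number from compound 1 to compound 2 (0.03 log units; within the scatter). Compound 3 `N#Cc1cccc(COc2ccc(-c3cc(CN4CCN(Cc5ccccc5F)CC4)no3)cc2)c1` gives 2300 nM in this assay; the difference between its core and the core of compound 1 is not broken down here. Compound 4 `N#Cc1cccc(COc2ccc(-c3cc(CN4CCN(Cc5cccc(F)c5)CC4)no3)cc2)c1` is not yet measured. It differs from compound 3 by 3-fluorophenyl in place of 2-fluorophenyl on a saturated chain carbon bound to an amine nitrogen in a ring. This is the same kind of change as that from compound 1 to compound 2, but it sits on a saturated chain carbon bound to an amine nitrogen in a ring rather than on a saturated chain carbon bound to an oxygen on an aromatic ring. Because the earlier step of a 1.1-fold lower number from compound 1 to compound 2 (0.03 log units; within the scatter) was small, a step of about a 1.0-fold lower number from compound 3 to compound 4 (0.02 log units; within the scatter) is expected here. Compound 4 is therefore estimated at 2200 nM in this assay, with a likely range from 1100 nM to 4400 nM.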

Compound 4, half-maximal inhibitory concentration: 2600 nM
For compound 4 the middle estimate is 1.2-fold (0.07 log units) below the measured one; low and high end bracket the measured number.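

In this assay the swap of 2-fluorobenzyl for 3-fluorobenzyl on a saturated chain carbon bound to an amine nitrogen in a ring gives a 1.1-fold higher number from compound 3 to compound 4 (0.05 log units; within the scatter) and so stays within the usual scatter of repeated measurements. Set beside the same kind of change on the other core, it shows no real difference between the two steps: the same change on two cores in this assay, a 1.1-fold lower number (0.03 log units; within the scatter) from compound 1 to compound 2 and a 1.1-fold higher number (0.05 log units; within the scatter) from compound 3 to compound 4, 1.2-fold (0.08 log units) apart, within the scatter of two such steps. This means that on these two cores, each with the change at its own place, moving the fluorine leaves the number essentially where it was, but it does not show that the change would carry over to a core where it has a real effect, and two steps this small cannot reveal a shared trend in either direction.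

The compounds shown leave open whether an amine, a carboxylic acid or a longer chain in place of the fluorine would move the number beyond the scatter. They also leave open how far the result holds on other cores in this series.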